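This account rests on a few compounds, and the source may have more. Where it says the series, first, only, none or still open, it means among the compounds named here.

Of the compounds shown here, three built on one shared core have been tested so far, each carrying a different aromatic group on that core. Compound 1, `COc1cc(C(=O)c2sc(-c3cccs3)cc2N)cc(OC)c1OC`, gives 9.4 nM in a functional assay on CCRF-CEM cells (Homo sapiens) for antiproliferative activity; a higher number here means a weaker inhibitor, a lower number a stronger inhibitor. Compound 2, `COc1cc(C(=O)c2sc(-c3cccc([N+](=O)[O-])c3)cc2N)cc(OC)c1OC`, gives 5.9 nM in this assay. Among the compounds with values here, the only single change measured between them is a 1.6-fold lower number from compound 1 to compound 2 (0.20 log units; within the scatter), with 3-nitrophenyl in place of thiophen-2-yl on an aromatic carbon, a difference too small to count as real.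

Compound 3, `COc1cc(C(=O)c2sc(-c3ccc(-c4ccccc4)cc3)cc2N)cc(OC)c1OC`, stands elsewhere. In this assay compound 3 reaches only a limit of the assay, > 10000 nM, so no number is known for it. This is the limit of > 10000 nM in this assay, at which 1 of the 3 values shown sits.

The next compound, compound 4, is `COc1cc(C(=O)c2sc(-c3ccc(Br)cc3)cc2N)cc(OC)c1OC`. The change from compound 3 is bromo in place of phenyl on an aromatic carbon. No measured step covers this exchange; the one measured step, within the scatter, concerns a different pair of groups, so nothing shown fixes the size of the step to come. Because compound 3 sits at a limit, > 10000 nM, the step can only be expected to be downward and large, and its size cannot be set from the numbers. Compound 4 is estimated at 25 nM, between 5 nM and 600 nM, which would mean an expected step of an at least 400-fold lower number from compound 3 to compound 4 (2.60 log units; beyond the scatter).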

Compound 4, half-maximal inhibitory concentration: 86 nM
Estimate against measurement, compound 4: 3.4-fold (0.54 log units) below; the range from low to high includes it.
By their numbers in this assay, from the lowest: compounds 2 and 1 (each within the scatter of the next); then compound 4. At a limit, above all of these: compound 3.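

Replacing phenyl with bromo on this six-membered aromatic ring of carbon only restores strong activity in this assay, with an at least 110-fold lower number from compound 3 to compound 4 (2.06 log units; beyond the scatter), so a substituent at this place does not by itself abolish activity, and the loss in compound 3 goes with the added phenyl. Even so, the bromophenyl group does not match the two aromatic groups tested before it, with a 15-fold higher number from compound 2 to compound 4 (1.16 log units; beyond the scatter) and a 9.1-fold higher number from compound 1 to compound 4 (0.96 log units; beyond the scatter), so the choice of aromatic group on the shared core matters more than the close values of compound 1 and compound 2 suggested. The first of these steps gives only a minimum size, because compound 3 stands at a limit of the assay and has no true number: the limit of > 10000 nM in this assay, at which 1 of the 4 values shown sits.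

The compounds shown leave open how activity changes across groups at this place that differ from both bromo and phenyl, such as a chloro, a methyl, a methoxy or an amine. They also leave open whether a phenyl attached elsewhere on the same ring would cost as much activity as it does in compound 3.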